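A few compounds are considered here, and "the series" means these few. Any claim that something is new, unique, unknown or untested is made for them only; others in the source may bear on it.

Compound 1 `NS(=O)(=O)c1cc(-c2nnc(CNC(=O)c3ccccc3)o2)c(Cl)cc1SCc1ccccc1`: 42000 nM
Compound 2 `NS(=O)(=O)c1cc(-c2nnc(CNS(=O)(=O)c3ccc(Cl)cc3)o2)c(Cl)cc1SCc1ccccc1`: 32000 nM

In a functional assay on HCT-116 cells (Homo sapiens) for cytotoxicity, read by MTT assay, with a stated time of 72 h (on this read-out higher numbers stand for weaker inhibition and lower numbers for stronger inhibition), compound 2 gives 32000 nM, and compound 1 cannot be told apart from it, since the step of a 1.3-fold lower number from compound 1 to compound 2 (0.12 log units; within the scatter) stays within the scatter. Compound 3 `NS(=O)(=O)c1cc(-c2nnc(/C=C/c3ccc(Br)cc3)o2)c(Cl)cc1SCc1ccccc1` differs from compound 2 by 2-(4-bromophenyl)ethenyl in place of (((4-chlorophenyl)sulfonyl)amino)methyl on an aromatic carbon. Within the data shown here, the only measured step swaps groups on the amine nitrogen, whereas this change removes that amine and its neighbours entirely, so no measured step bears on it. The expectation for compound 3 is therefore set at no clear move, a 1.1-fold lower number from compound 2 to compound 3 (0.03 log units; within the scatter), with a wide range. Compound 3 is estimated at 30000 nM, between 8000 nM and 100000 nM.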

Compound 3, half-maximal inhibitory concentration: 15000 nM
Beside the measured number, compound 3's estimate is 2.0-fold (0.30 log units) above it; the measured number falls inside the stated range.
By their numbers in this assay, from the lowest: compound 3; then compounds 2 and 1 (each within the scatter of the next).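

In this assay the whole arm on this aromatic carbon can be exchanged with a readable result: 2-(4-bromophenyl)ethenyl gives a 2.1-fold lower number from compound 2 to compound 3 (0.33 log units; beyond the scatter) and also a 2.8-fold lower number from compound 1 to compound 3 (0.45 log units; beyond the scatter), both modest. The earlier swap on the amine nitrogen gave no readable step, and this entering group carries no hydrogen-bond donor or acceptor. No measured evidence explains these steps. On these data alone, it remains open whether the bromine or the ethenyl link accounts for them. A saturated ethyl link, or a carboxylic acid in place of the bromine, would help separate the two.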